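Bromo to phenyl at the tolerated limit

The source may hold more compounds than are shown below. What is called first, only, known or untested is meant among the compounds shown, and "the series" means these compounds.

In an ADME assay on H9c2 cells (Rattus norvegicus) for cytotoxicity, read by resazurin assay, with a stated time of 72 h (a higher number here means that more compound is tolerated, a lower number that less compound is tolerated), compound 1 (`C/C(=N\Nc1nc(-c2ccccc2)cs1)c1ccc(Cl)c(Cl)c1`) gives > 50000 nM as a limit of the assay. Compound 2 (`C/C(=N\Nc1nc(-c2ccc(F)cc2)cs1)c1ccc(Cl)c(Cl)c1`) gives > 50000 nM as a limit too. Compound 3 (`C/C(=N\Nc1nc(-c2ccc(Br)cc2)cs1)c1ccc(Cl)c(Cl)c1`) gives > 50000 nM as a limit as well, so it has no number of its own. The whole measured set stands at the limit of > 50000 nM in this assay, at which 3 of the 3 values shown sit, and no half-maximal cytotoxic concentration has yet been read.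

Compound 4 (`C/C(=N\Nc1nc(-c2ccc(-c3ccccc3)cc2)cs1)c1ccc(Cl)c(Cl)c1`) follows through the change phenyl in place of bromo on an aromatic carbon and so carries phenyl in place of bromo on an aromatic carbon, para to a large group. The measured steps that bear on it are a step that the two limits leave unreadable from compound 1 to compound 2 and a step that the two limits leave unreadable from compound 1 to compound 3 and a step that the two limits leave unreadable from compound 2 to compound 3 so no size can be carried over from them. Hydrogen, fluoro and bromo give the same limit, but phenyl is a larger group than any of these, which leaves some room downward. No step beyond the scatter is expected in this assay and compound 4 will most likely stay at the limit. The expected step is a number no higher from compound 3 to compound 4 (the limit leaves the size open) as an estimate. For compound 4 the estimated value is 50000 nM with an expected range from 20000 nM to 100000 nM in this estimate.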

Compound 4, half-maximal cytotoxic concentration: > 50000 nM
Compound 4 ended at the assay's limit (the forecaster's own chance of this, stated with the estimate: 75%); the middle value sits exactly at the limit.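

No step to compound 4 from compound 1, compound 2 or compound 3 can be read in this assay, and the whole series stays at a single limit: the limit of > 50000 nM in this assay, at which 4 of the 4 values shown sit.

The compounds shown leave open what half-maximal cytotoxic concentration any of them has, and whether any other group in that place would give a readable number.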